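Swapping a carbamoyl for a methylsulfonyl: solubility outlook

The compounds below may be only part of what the source reports. "The series", "measured", "known", "first", "only" and "open" are said of these compounds alone.

Measured compounds:
compound 1 `NC(=O)C[C@H](NC(=O)c1ccc(C#Cc2ccccc2)cc1)C(=O)NO`: 61000 nM
compound 2 `O=C(NC1(C(=O)NO)CCN(Cc2ccccc2)CC1)c1ccc(C#Cc2ccccc2)cc1`: < 1000 nM

Of the compounds shown here, two sharing the same core have been measured in a physicochemical assay for solubility; on this read-out lower numbers stand for lower solubility and higher numbers for higher solubility. Among the compounds with values here, compound 1 gives 61000 nM and is the only compound with a full number in this assay. For compound 2 the read-out is < 1000 nM, which is a limit of the assay rather than a measured number. Within the data shown here, the two values therefore cannot be set against each other as a step, and no step between measured compounds is available; all that can be said is that one of the two values sits at the limit of < 1000 nM in this assay, at which 1 of the 2 values shown sits.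

Compound 3 `CS(=O)(=O)C[C@H](NC(=O)c1ccc(C#Cc2ccccc2)cc1)C(=O)NO` is not yet measured. It differs from compound 1 in one place: methylsulfonyl in place of carbamoyl on a saturated chain carbon, two bonds along the chain from an amide-type nitrogen and a carbonyl carbon. The group that leaves and the group that enters are of similar size, so no large movement in this assay is expected from this change; the step from compound 1 to compound 3 is estimated to stay within the usual scatter, at a 1.4-fold lower number from compound 1 to compound 3 (0.13 log units; within the scatter). On that basis compound 3 is expected to give about 45000 nM in this assay, most likely between 12000 nM and 150000 nM.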

Compound 3, solubility: 2000 nM
Compound 3: the middle estimate sits 23-fold (1.35 log units) above what was measured; measured number below the stated range.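

In this assay, this one-place change on a saturated chain carbon turns out to matter a great deal: it brings a 31-fold lower number from compound 1 to compound 3 (1.48 log units; beyond the scatter). Within the data shown here, the earlier compounds offered no step at all, so this is the first sign that the read-out responds strongly at this position, even to an exchange of two groups as close in heavy-atom count as carbamoyl, with 3, and methylsulfonyl, with 4. The count also shows that carbamoyl carries 1 hydrogen-bond donor and methylsulfonyl 0, but no measurement shown here ties the step to that difference or to any other.

As far as these compounds go, it remains open whether this large step reflects something particular to carbamoyl or to methylsulfonyl, a question that an amine or a carboxylic acid on the same saturated chain carbon, or a carbamoyl on a longer chain, could help to settle. Among these compounds, compound 2 reads < 1000 nM, which is a limit, so it adds no step to this picture.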